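The source may hold more compounds than are shown below. What is called first, only, known or untested is meant among the compounds shown, and "the series" means these compounds.

Measured in a functional assay on SMMC-7721 cells (Homo sapiens) for inhibition, read by CCK-8 assay, with a stated time of 72 h, tested at 8 uM; a lower number here means less inhibition of growth, a higher number more inhibition of growth at the concentration tested:
- Compound 1 `Cc1cc(C)cc(SCc2ccc(/C=C/C(=O)Nc3ccccc3N)cc2)c1`: 7.13%
- Compound 2 `Nc1ccccc1NC(=O)/C=C/c1ccc(CSc2cccc(F)c2)cc1`: 8.25%
- Compound 3 `Nc1ccccc1NC(=O)/C=C/c1ccc(CSc2cccc3ccccc23)cc1`: 18.3%

Compound 3 stands highest of the three in this assay. The data show a number 10.1 percentage points higher from compound 2 to compound 3 (beyond the scatter), and also a number 11.2 percentage points higher from compound 1 to compound 3 (beyond the scatter). The two lower compounds do not separate, with a number 1.1 percentage points higher from compound 1 to compound 2 (within the scatter).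

Compound 4 `Nc1ccccc1NC(=O)/C=C/c1ccc(CSCCc2ccccc2)cc1` keeps the shared core and changes only the group on the sulfur, with phenethyl in place of naphthalen-1-yl on a sulfur. Among the compounds with values here, no measured compound carries phenethyl, so the data hold no direct precedent for it. The nearest guidance comes from the two steps that involve naphthalen-1-yl, since each compares it with a group of the phenyl kind. If phenethyl behaves like 3,5-dimethylphenyl or 3-fluorophenyl, compound 4 should fall back towards compound 1 and compound 2, reversing much of a number 10.1 percentage points higher from compound 2 to compound 3 (beyond the scatter). This is only an analogy. Within the data shown here, the chain in phenethyl has no measured counterpart, so the range stays wide and a smaller drop remains possible.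

The expected change is a number 8.3 percentage points lower from compound 3 to compound 4 (within the scatter), a modest move to a lower number. The estimate for compound 4 is 10%, within an expected range from 2% to 21%.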

Compound 4, percent growth inhibition at one concentration: 15.8%
For compound 4 the middle estimate is 5.8 percentage points below the measured one, and the stated range covers the measured number.
By their numbers in this assay, from the lowest: compounds 1, 2, 4 and 3 (each within the scatter of the next, the first and the last beyond it).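

In this assay, the change from naphthalen-1-yl to phenethyl on the sulfur gives a number 2.5 percentage points lower from compound 3 to compound 4 (within the scatter), so at this position a group with one six-membered aromatic ring on a saturated chain cannot be told apart from the group with two such rings. Compound 4 is not separated from the two compounds with a ring directly on the sulfur either, with a number 7.6 percentage points higher from compound 2 to compound 4 (within the scatter) and a number 8.7 percentage points higher from compound 1 to compound 4 (within the scatter), which means that the clear gap between naphthalen-1-yl and those two groups does not extend to phenethyl, and compound 4 lies within the scatter of both sides of that gap. The data offer no measurement that accounts for these numbers.

Going by these compounds, what remains open is whether growth inhibition at this position follows the length of the chain, as a benzyl group or a longer phenylpropyl chain on the sulfur would show. On these data alone, it is also open how a chain ending in an amine or a carboxylic acid would compare with phenethyl, and whether naphthalen-2-yl would match naphthalen-1-yl.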